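The source may report more compounds than this note shows. Statements on the series, on what has been measured and on what is new or still open speak of the compounds shown alone.

Compound 1 `CCOc1cc(CN2CCC(NC(=O)c3ccc(Cl)nc3)CC2)cc(OCC)c1-c1ccc(F)cc1` gives 3.55
Compound 2 `CCOc1cc(CN2CCC(NC(=O)c3cncc(C)c3)CC2)cc(OCC)c1-c1ccc(F)cc1` gives 4.01

In a physicochemical assay for lipophilicity, read by spectrophotometry, measured as octanol-water partition, at pH 7.4 (on this read-out higher numbers stand for higher lipophilicity and lower numbers for lower lipophilicity), compound 1 stands at 3.55 and compound 2 at 4.01, the higher of the two measured compounds, and the gap between them lies beyond the scatter. Compound 3 `CCOc1cc(CN2CCC(NC(=O)c3ccc(N)nc3)CC2)cc(OCC)c1-c1ccc(F)cc1` is not yet measured. Among the compounds with values here, the change from compound 2 is 6-aminopyridin-3-yl in place of 5-methylpyridin-3-yl on a carbonyl carbon on the same carbonyl carbon that varies in the one measured step. That step, a number 0.46 log units higher from compound 1 to compound 2 (beyond the scatter), is modest and ends on the 5-methylpyridin-3-yl group, which compound 3 gives up. Compound 3 instead carries a 6-aminopyridin-3-yl group, and compound 1 its 6-chloropyridin-3-yl group. One step is thin evidence, so the range stays wide. A downward move of modest or somewhat larger size is expected, estimated as a number 0.81 log units lower from compound 2 to compound 3 (beyond the scatter) in this assay. For compound 3 the estimated value is 3.2 with an expected range from 2.7 to 3.7 in this assay.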

Compound 3, distribution coefficient: 3.15
Compound 3: the middle estimate sits 0.05 log units above what was measured, within the range that was stated.
By their numbers in this assay, from the lowest: compound 3; then compound 1; then compound 2.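

In this assay, the carbonyl carbon now carries three different pyridinyl groups, and the reading moves down as well as up: 6-aminopyridin-3-yl in place of 5-methylpyridin-3-yl gives a number 0.86 log units lower from compound 2 to compound 3 (beyond the scatter), and compound 3 is the lowest of the three. Amino in place of chloro on an aromatic carbon gives a number 0.40 log units lower from compound 1 to compound 3 (beyond the scatter), so this single exchange on the pyridine ring also shifts the reading beyond the scatter. No measurement here accounts for either step.

Open, as far as these compounds go, is how a methoxy group, a dimethylamino group or a carboxylic acid on that aromatic carbon would read in this assay. Also open, from the compounds shown here alone, is where a plain phenyl group on the carbonyl carbon would fall relative to these three pyridinyl groups.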